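The compounds below may be only part of what the source reports. "The series", "measured", "known", "first", "only" and "open" are said of these compounds alone.

The series shares one core, seen in compound 1 `CN(C)CCCOc1ccc(CN2CC[C@H](NC(=O)c3ccco3)C2)cc1`, compound 2 `CC(C)C[C@H](NC(=O)c1ccc2ccccc2n1)C(=O)N[C@H]1CCN(Cc2ccc(OCCCN(C)C)cc2)C1` and compound 3 `CC(C)C[C@H](NC(=O)c1ccc(Br)cc1)C(=O)N[C@H]1CCN(Cc2ccc(OCCCN(C)C)cc2)C1`. In an assay on HEK293 cells for binding affinity to Urotensin-2 receptor (Homo sapiens), read by radioligand binding (on this read-out lower numbers stand for stronger inhibition and higher numbers for weaker inhibition), compound 1 reaches only a limit, < 10000 nM. In this assay compound 2 gives 631 nM. In this assay compound 3 gives 200 nM, the lowest of the two numbers shown, and the step of a 3.2-fold lower number from compound 2 to compound 3 (0.50 log units; beyond the scatter) lies beyond the scatter. Compound 4 `CC(C)C[C@H](NC(=O)c1ccccc1)C(=O)N[C@H]1CCN(Cc2ccc(OCCCN(C)C)cc2)C1` is the next member. Against compound 3 it shows (hydrogen in place of bromo on an aromatic carbon), so the change reads 4-bromophenyl to phenyl on the carbonyl carbon. No measured step removes a bromo at this place; the single step shown, a 3.2-fold lower number from compound 2 to compound 3 (0.50 log units; beyond the scatter), swaps the whole aryl group and only tells that the bromophenyl amide sits at the better end. For compound 4 a modest upward step is expected, a 2.3-fold higher number from compound 3 to compound 4 (0.35 log units; beyond the scatter), not far past the scatter. Compound 4 is therefore expected to give about 450 nM in this assay, between 150 nM and 1500 nM.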

Compound 4, inhibition constant: 501 nM
For compound 4 the middle estimate is 1.1-fold (0.05 log units) below the measured one; the range from low to high includes it.
By their numbers in this assay, from the lowest: compound 3; then compounds 4 and 2 (each within the scatter of the next).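

In this assay the bromo on the aromatic carbon, para to a large group, is the part that counts: hydrogen in its place gives a 2.5-fold higher number from compound 3 to compound 4 (0.40 log units; beyond the scatter) and is the only step shown that changes a single atom on the aryl amide. The phenyl and quinolin-2-yl amides stand level, with a 1.3-fold lower number from compound 2 to compound 4 (0.10 log units; within the scatter), so the gap that compound 3 opens over compound 2 goes with the bromo and not with replacing the quinolin-2-yl by a six-membered ring as such. No measurement shown bears on why this bromo matters.

Going by these compounds, whether chloro, methoxy or trifluoromethyl in the same place would match the bromo stays open. So does the reading with an amine or a carboxylic acid there, or with a longer chain in place of the dimethylaminopropoxy group.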